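Adding a second chloro where trifluoromethyl had been

The source may report more compounds than this note shows. Statements on the series, on what has been measured and on what is new or still open speak of the compounds shown alone.

Of the compounds shown here, three built on one shared core have been measured in a functional assay on MCF7 cells (Homo sapiens) for antiproliferative activity, read by MTT assay, with a stated time of 48 h; a higher number here means a weaker inhibitor, a lower number a stronger inhibitor. Compound 1 `O=C(Nc1cccc(/C=C/C(=O)c2nc3ccccc3[nH]2)c1)c1cccc(Cl)c1` gives 7840 nM. Compound 2 `O=C(/C=C/c1cccc(NC(=O)c2ccccc2Br)c1)c1nc2ccccc2[nH]1` gives 4520 nM. Compound 3 `O=C(Nc1cccc(/C=C/C(=O)c2nc3ccccc3[nH]2)c1)c1cccc(C(F)(F)F)c1` gives 21500 nM, the highest number of the three and thus the weakest inhibitor here, since the steps of a 2.7-fold higher number from compound 1 to compound 3 (0.44 log units; beyond the scatter) and a 4.8-fold higher number from compound 2 to compound 3 (0.68 log units; beyond the scatter) both lie beyond the scatter.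

Compound 4 `O=C(Nc1cccc(/C=C/C(=O)c2nc3ccccc3[nH]2)c1)c1cc(Cl)cc(Cl)c1` has not yet been measured. It differs from compound 3 in one place: 3,5-dichlorophenyl in place of 3-(trifluoromethyl)phenyl on a carbonyl carbon. Among the measured compounds shown here, the step that bears most directly on this change is the one from compound 1 to compound 3, where a chloro became a trifluoromethyl and the number rose, a 2.7-fold higher number from compound 1 to compound 3 (0.44 log units; beyond the scatter). For the measured compounds named here, compound 4 reverses that swap and adds a second chloro on the same ring, for which no measured step exists. The expectation is therefore that compound 4 moves back toward compound 1, giving a lower number than compound 3 in this assay, with the step of a 3.1-fold lower number from compound 3 to compound 4 (0.49 log units; beyond the scatter) expected to be of modest size.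

Compound 4 is estimated at 7000 nM, with a likely range from 2500 nM to 20000 nM.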

Compound 4, half-maximal inhibitory concentration: > 100000 nM
Compound 4: only a limit was reported; the forecaster's own chance of this, stated with the estimate: 5%; middle value at least 14-fold (1.15 log units) away from the limit.
By their numbers in this assay, from the lowest: compounds 2 and 1 (each within the scatter of the next); then compound 3. At a limit, above all of these: compound 4.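

Compound 4 gives no number, only a limit: the limit of > 100000 nM in this assay, at which 1 of the 4 values shown sits.

Adding a second chloro to the ring of compound 1 is a single change, yet it gives an at least 12-fold higher number from compound 1 to compound 4 (1.10 log units; beyond the scatter), which is large, and the 3,5-dichlorophenyl group also stands well apart from the other two groups on this carbonyl carbon, with an at least 4.6-fold higher number from compound 3 to compound 4 (0.66 log units; beyond the scatter) and an at least 22-fold higher number from compound 2 to compound 4 (1.34 log units; beyond the scatter). The earlier compounds shown here, each with one group on this ring, all gave measured numbers, and the biggest step among them was modest, so they did not show that one more chloro here could cost this much.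

The compounds shown leave open whether this loss belongs to chloro itself or to any ring carrying two groups, a question that a ring with a methoxy or an amine as its second group would help to settle. They also give no reason for the loss, and a single further compound would not supply one without a measurement beyond this cell assay.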